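Nitro-substituted bicyclic cores: Vero cell cytotoxicity notes

A few compounds are considered here, and "the series" means these few. Any claim that something is new, unique, unknown or untested is made for them only; others in the source may bear on it.

Measured compounds:
compound 1, `CCCNc1nc(=O)c2cc([N+](=O)[O-])cc([N+](=O)[O-])c2s1`, "not determined" (no result reported)
compound 2, `CC(C)(C)Nc1nc(=O)c2cc([N+](=O)[O-])cc([N+](=O)[O-])c2s1`, "not determined" (no result reported)
compound 3, `CCCNc1nc(=O)c2cc(C(F)(F)F)cc([N+](=O)[O-])c2s1`, > 100000 nM

In an ADME assay on Vero cells (Chlorocebus sabaeus) for cytotoxicity, read by MTT assay, with a stated time of 72 h (on this read-out lower numbers stand for stronger inhibition and higher numbers for weaker inhibition), compound 1 and compound 2 have no reported number. Compound 3 is recorded only as a limit of the assay, > 100000 nM, and this is the sole entry with any numerical content, in line with the limit of > 100000 nM in this assay, at which 1 of the 3 values shown sits. Compound 3 therefore stands at the edge of what this assay resolves, with nothing on either side of it to compare against.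

The next compound, compound 4, `O=c1nc(NC2CC2)sc2c([N+](=O)[O-])cc(C(F)(F)F)cc12`, differs from compound 3 in one place: cyclopropyl in place of propyl on a nitrogen on an aromatic ring. Within the data shown here, no pair of measured compounds shares this change, so no measured step shows how it acts here. The expectation is a step of no size beyond the scatter, in no particular direction, since compound 3 already sits at the limit > 100000 nM and a small change of the propylamino group to cyclopropylamino gives no ground for expecting anything else. The estimated step from compound 3 to compound 4 is a number no higher from compound 3 to compound 4 (the limit leaves the size open). Compound 4 is therefore expected at 100000 nM, with a range from 30000 nM to 300000 nM, most probably reported again only as a limit.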

Compound 4, half-maximal inhibitory concentration: > 100000 nM
Compound 4 ended at the assay's limit (the forecaster's own chance of this, stated with the estimate: 80%); the middle value lies on the limit itself.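

Compound 3 and compound 4 are both recorded only as limits in this assay, so the change from propylamino to cyclopropylamino gives no readable step: the limit of > 100000 nM in this assay, at which 2 of the 4 values shown sit.

The compounds shown leave open whether this change has any effect on cytotoxicity, and whether any compound in the series gives a number short of that limit.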